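Restoring the Benzyl Arm: What Compound 3 Should Give

The compounds below may be only part of what the source reports. "The series", "measured", "known", "first", "only" and "open" are said of these compounds alone.

Compound 1, `COc1cc(Oc2cccc(Nc3ccccc3)c2)cc(OC)c1CNCc1ccccc1`: 4070 nM
Compound 2, `CNCc1c(OC)cc(Oc2cccc(Nc3ccccc3)c2)cc1OC`: a limit only, > 20000 nM

In a functional assay on HCT-116 cells (Homo sapiens) for inhibition, read by MTT assay, with a stated time of 72 h (on this read-out lower numbers stand for stronger inhibition and higher numbers for weaker inhibition), compound 1 gives 4070 nM. Compound 2 reaches only the limit of this assay, > 20000 nM, so among the numbers shown it stands at the weak end without a measured value of its own. The step of an at least 4.9-fold higher number from compound 1 to compound 2 (0.69 log units; beyond the scatter) is therefore open-ended and runs into that limit (the limit of > 20000 nM in this assay, at which 1 of the 2 values shown sits).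

Compound 3, `COc1cc(Oc2cccc(Nc3ccccc3)c2)cc(OC)c1CNCc1ccc(C)cc1`, differs from compound 2 by 4-methylphenyl in place of hydrogen on a saturated chain carbon bound to an amine nitrogen. Within the data shown here, this change largely reverses the measured step, restoring an aromatic ring on the chain carbon bound to the amine nitrogen, now carrying a methyl group; the only step that bears on it is the loss seen from compound 1 to compound 2, so a gain of similar size back toward compound 1 is expected. Compound 3 is thus expected to give 3500 nM, within 1200 nM to 12000 nM. That estimate means an expected step of an at least 5.7-fold lower number from compound 2 to compound 3 (0.75 log units; beyond the scatter).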

Compound 3, half-maximal inhibitory concentration: 13800 nM
Compound 3: middle estimate off by 3.9-fold (0.60 log units), on the low side; the measured number lies above the stated range.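

With an aromatic ring back on the saturated chain carbon bound to an amine nitrogen, this assay gives an at least 1.4-fold lower number from compound 2 to compound 3 (0.16 log units; that floor lies within the scatter) and this step has only a floor, since compound 2 stands at a limit of the assay and not at a number: the limit of > 20000 nM in this assay, at which 1 of the 3 values shown sits.

Among these compounds, what the earlier compounds did not show is that the ring's substitution matters at this position: methyl in place of hydrogen on an aromatic carbon gives a 3.4-fold higher number from compound 1 to compound 3 (0.53 log units; beyond the scatter) and so a ring alone does not bring back the number of compound 1.

The compounds shown leave open whether a chlorine atom or a methoxy group on that aromatic carbon would act as methyl does. They also leave open how a phenethyl group on the amine nitrogen would read out.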